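Replacing piperidin-1-yl with dimethylamino in compound 3

A few compounds are considered here, and "the series" means these few. Any claim that something is new, unique, unknown or untested is made for them only; others in the source may bear on it.

Measured in an ADME assay on HepG2 cells (Homo sapiens) for inhibition, read by luminescence and CellTiter-Glo, with stated times of 24 h and 48 h; a lower number here means a stronger inhibitor, a higher number a weaker inhibitor
Compound 1 `Cc1ccc(C(=O)N(CC(=O)NCc2ccccc2)Cc2ccc(C(=O)NO)cc2)c(C)c1` gives 3710 nM
Compound 2 `Cc1ccc(C(=O)N(CC(=O)NC2CCCCC2)Cc2ccc(C(=O)NO)cc2)c(C)c1` gives 8330 nM
Compound 3 `Cc1cc(C)cc(C(=O)N(CC(=O)N2CCCCC2)Cc2ccc(C(=O)NO)cc2)c1` gives 35000 nM

Compound 3 has the highest number of the three, at 35000 nM in this assay testing. Compound 4 `Cc1cc(C)cc(C(=O)N(CC(=O)N(C)C)Cc2ccc(C(=O)NO)cc2)c1` carries dimethylamino in place of piperidin-1-yl on a carbonyl carbon, a change counted as dimethylamino in place of piperidin-1-yl on a carbonyl carbon and made nowhere else. The closest measured step is a 2.2-fold higher number from compound 1 to compound 2 (0.35 log units; beyond the scatter) for cyclohexyl in place of benzyl on an amide-type nitrogen, which is modest. For the measured compounds named here, that pair also differs from compound 3 in how its methyl groups are arranged, and no measured compound carries dimethylamino, so the guidance is weak. The estimated step of a 1.1-fold higher number from compound 3 to compound 4 (0.06 log units; within the scatter) is therefore expected to stay within the scatter, with any shift more likely upward. Compound 4 is estimated at 40000 nM with a range from 15000 nM to 100000 nM in this assay testing.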

Compound 4, half-maximal inhibitory concentration: > 50000 nM
Compound 4: only a limit was reported; the forecaster's own chance of this, stated with the estimate: 25%; at least 1.2-fold (0.09 log units) between middle value and limit.
By their numbers in this assay, from the lowest: compound 1; then compound 2; then compound 3. At a limit, above all of these: compound 4.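

In this assay compound 4 gives > 50000 nM as a limit and not as a number. Dimethylamino in place of piperidin-1-yl on a carbonyl carbon gives an at least 1.4-fold higher number from compound 3 to compound 4 (0.15 log units; that floor lies within the scatter) and so removing the ring from this group did not bring the number down. This position therefore yields a floor for the step and not its full size: the limit of > 50000 nM in this assay, at which 1 of the 4 values shown sits.

From the compounds shown here alone, what a morpholin-4-yl or pyrrolidin-1-yl group would give on this carbonyl carbon stays open. So does how far the step from compound 3 to compound 4 extends beyond its floor.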